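The compounds below may be only part of what the source reports. "The series", "measured", "known", "first", "only" and "open" are said of these compounds alone.

Of the compounds shown here, two that share one core have been measured in a functional assay (aorta) with Rattus norvegicus as the target; a higher number here means a more potent compound, by a factor of ten per unit of this negative logarithm, a lower number a less potent compound. Compound 1 `CC1(C)C=C(n2ccccc2=O)c2cc(C(=O)c3cccs3)ccc2O1` gives 6.4, and compound 2 `CC1(C)C=C(n2ccccc2=O)c2cc(C(=N)NO)ccc2O1` gives 5.99. Going by the values given here, compound 2 thus stands lowest of the two numbers, with compound 1 as its only neighbour, and the step of a number 0.41 log units lower from compound 1 to compound 2 (beyond the scatter) is the single change measured so far.

Compound 3 `CC1(C)C=C(n2ccccc2=O)c2cc(C=C(C#N)C#N)ccc2O1` has not yet been measured. It differs from compound 2 in one place: a group of 6 heavy atoms (4 carbon, 2 nitrogen; no ring) in place of a group of 4 heavy atoms (1 carbon, 2 nitrogen, 1 oxygen; no ring), on an aromatic carbon. Among the compounds with values here, no measured step covers the 2,2-dicyanoethenyl group, so the expectation rests only on the observation that exchanging the group on this aromatic carbon moved the number by a modest amount in the measured pair. The step is expected to be small, a number 0.21 log units higher from compound 2 to compound 3 (within the scatter), with its direction uncertain. Compound 3 is therefore estimated at 6.2 in this assay, within a range from 5.5 to 6.9.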

Compound 3, logarithm of the reciprocal of the active concentration, log(1/C): 6.95
Compound 3: middle estimate off by 0.75 log units, on the low side; the whole stated range lies below it.
By their numbers in this assay, from the lowest: compound 2; then compound 1; then compound 3.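

Placing 2,2-dicyanoethenyl on this aromatic carbon gives a number 0.96 log units higher from compound 2 to compound 3 (beyond the scatter) and a number 0.55 log units higher from compound 1 to compound 3 (beyond the scatter) in this assay, so the position can carry a clear gain as well as the loss seen earlier. Going by these compounds alone, the order of the three compounds follows neither the presence of a ring nor group size: the groups in compound 2 and compound 3 both lack a ring yet fall on either side of the ring-bearing group in compound 1, and the largest group is not the one with the highest number. Nothing available explains why this group gives the highest number.

Going by these compounds, whether a single nitrile, a carboxylic acid or an amine on this carbon would match 2,2-dicyanoethenyl remains open. So does whether a longer chain carrying the two nitriles would keep the gain.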